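Stretching the side chain of compound 3

A few compounds are considered here, and "the series" means these few. Any claim that something is new, unique, unknown or untested is made for them only; others in the source may bear on it.

In a functional assay, read by spectrophotometry (a higher number here means that more compound is needed for the effect, a lower number that less compound is needed), compound 1 (`COc1ccc(-c2cc(=O)c3ccc(O)cc3o2)cc1OC`) gives 22.4 nM and compound 2 (`COc1cc(-c2cc(=O)c3ccc(O)cc3o2)cc(OC)c1OC`) gives 26.4 nM while compound 3 (`COc1ccc(-c2cc(=O)c3ccc(OCCCN4CCC(C)CC4)cc3o2)cc1`) gives 26.6 nM and these three values lie within the scatter of one another. Compound 4 (`COc1ccc(-c2cc(=O)c3ccc(OCCCCN4CCC(C)CC4)cc3o2)cc1`) differs from compound 3 in one place ((4-methylpiperidin-1-yl)methyl in place of 4-methylpiperidin-1-yl on a saturated chain carbon, three bonds along the chain from an oxygen on an aromatic ring): (4-methylpiperidin-1-yl)methyl stands in place of 4-methylpiperidin-1-yl on a saturated chain carbon, three bonds along the chain from an oxygen on an aromatic ring. Going by the values given here, no measured pair varies this chain. Among the compounds with values here, the only measured step (a 1.2-fold higher number from compound 1 to compound 2 (0.07 log units; within the scatter)) adds a methoxy in place of hydrogen on an aromatic carbon, stays within the scatter, and bears on the chain only indirectly. Resting on compound 3 at 26.6 nM and on that single small step, no change beyond the scatter is expected in this assay for the longer chain. The estimated step is small (a 1.1-fold higher number from compound 3 to compound 4 (0.02 log units; within the scatter)). Compound 4 is expected at 28 nM within an estimated range (11 nM to 70 nM).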

Compound 4, half-maximal effective concentration: 28.1 nM
The estimate for compound 4 lay 1.0-fold (0.00 log units) below the measured number; the measured number falls inside the stated range.
By their numbers in this assay, from the lowest: compounds 1, 2, 3 and 4 (each within the scatter of the next).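

Going by these compounds alone, replacing 4-methylpiperidin-1-yl with (4-methylpiperidin-1-yl)methyl, on a saturated chain carbon, three bonds along the chain from an oxygen on an aromatic ring, gives the first measured change to this chain: in this assay the result is a 1.1-fold higher number from compound 3 to compound 4 (0.02 log units; within the scatter) and so shows no real change. This position therefore accepts this one lengthening without a shift that can be told from the scatter, though a single step says nothing about a trend with chain length. Nothing available gives a reason for this outcome.

Still open, on these data alone, is whether a longer chain, or a morpholine or a carboxylic acid in place of the 4-methylpiperidin-1-yl, would also leave the number in this assay within the scatter. Also open, as far as these compounds go, is whether the same lengthening would read alike with the aromatic methoxy groups of compound 2.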